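Sulfation of the primary hydroxyl across two glycoside cores

The compounds below may be only part of what the source reports. "The series", "measured", "known", "first", "only" and "open" are said of these compounds alone.

Measured compounds:
compound 1 `C=CCCC(=O)N[C@H]1[C@@H](OCCc2ccccc2)O[C@H](CO)[C@@H](O)[C@@H]1O` — > 50 uM
compound 2 `CCCCCCCCCCCCCCCCO[C@H]1O[C@H](COCC(CO)(CO)COS(=O)(=O)O)[C@@H](O)[C@H](O)[C@H]1NC(=O)CCCC` — 3.2 uM
compound 3 `CCCCCCCCCCCCCCCCO[C@H]1O[C@H](COCC(CO)(CO)CO)[C@@H](O)[C@H](O)[C@H]1NC(=O)CCCC` — 27.3 uM

In a functional assay on U-373MG ATCC cells (Homo sapiens), read by thymidine incorporation (on this read-out higher numbers stand for weaker inhibition and lower numbers for stronger inhibition), compound 3 gives 27.3 uM. Compound 2 differs from it by sulfo in place of hydrogen on an oxygen on a saturated carbon, and this change gave an 8.5-fold lower number from compound 3 to compound 2 (0.93 log units; beyond the scatter).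

For compound 1 the value > 50 uM in this assay is a limit, not a number. Its standing rests on (the limit of > 50 uM in this assay, at which 1 of the 3 values shown sits), so the true starting point of compound 1 is not known.

Compound 4 `C=CCCC(=O)N[C@H]1[C@@H](OCCc2ccccc2)O[C@H](COS(=O)(=O)O)[C@@H](O)[C@@H]1O` has not been measured. It differs from compound 1 by sulfo in place of hydrogen on an oxygen on a saturated carbon. The place of the change is described in the same words as for the step from compound 3 to compound 2, so it is the same change. How the core of compound 1 differs from the core of compound 3 is not broken down here.

In this assay the step from compound 1 to compound 4 is expected to be an at least 3.3-fold lower number from compound 1 to compound 4 (0.52 log units; beyond the scatter), resting on the measured step of an 8.5-fold lower number from compound 3 to compound 2 (0.93 log units; beyond the scatter) and on the limit of > 50 uM in this assay, at which 1 of the 3 values shown sits, for compound 1, which leaves the starting value open. Compound 4 is estimated at 15 uM, with a likely range of 4 uM to 60 uM.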

Compound 4, concentration for 50% inhibition: > 50 uM
Compound 4 was reported as a limit; the forecaster's own chance of this, stated with the estimate: 35%; middle value at least 3.3-fold (0.52 log units) away from the limit.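

In this assay compound 4 gives > 50 uM, which is a limit. Compound 1 is also reported as a limit, so no step can be read between compound 1 and compound 4: the limit of > 50 uM in this assay, at which 2 of the 4 values shown sit.

Still open, as far as these compounds go, is whether sulfo in place of hydrogen on an oxygen on a saturated carbon changes the number at all on the core of compound 1, as it does between compound 3 and compound 2.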